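A few compounds are considered here, and "the series" means these few. Any claim that something is new, unique, unknown or untested is made for them only; others in the source may bear on it.

In a functional assay on HCT-116 cells (Homo sapiens) for inhibition, read by sulforhodamine B assay, with a stated time of 48 h, tested at 50 uM (a lower number here means less inhibition of growth, a higher number more inhibition of growth at the concentration tested), compound 2 `COc1ccc([C@@H]2CC(=O)c3cc(CC=C(C)C)c(OC)cc3O2)cc1` gives 68% and compound 1 `COc1ccc([C@@H]2C/C(=N/OCc3cn(-c4ccc(O)cc4)nn3)c3cc(CC=C(C)C)c(OC)cc3O2)cc1` gives 65% while compound 3 `COc1ccc([C@@H]2C/C(=N/OCc3cn(-c4ccc(C(=O)c5ccccc5)cc4)nn3)c3cc(CC=C(C)C)c(OC)cc3O2)cc1` gives 52% as the lowest of the three numbers, beyond the scatter from both of the others. Compound 4 `COc1ccc([C@@H]2C/C(=N/OCc3cn(-c4ccc(C#N)cc4)nn3)c3cc(CC=C(C)C)c(OC)cc3O2)cc1` has not yet been measured. It differs from compound 3 by cyano in place of benzoyl on an aromatic carbon, para to a large group (cyano in place of benzoyl on an aromatic carbon). For the measured compounds named here, one measured step bears on this change: benzoyl in place of hydroxy on an aromatic carbon gave a number 13 percentage points lower from compound 1 to compound 3 (beyond the scatter) and that step is modest. Going by the values given here, no measured compound carries cyano, so this single step is only a weak guide. It suggests that losing the benzoyl may recover part of that drop, though not necessarily by a margin beyond the scatter. The expected step is a number 8 percentage points higher from compound 3 to compound 4 (within the scatter) and so a small rise. For compound 4 the estimated value is 60% with an expected range from 49% to 71% in this estimate.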

Compound 4, percent growth inhibition at one concentration: 50%
The estimate for compound 4 lay 10 percentage points above the measured number, and the stated range covers the measured number.
By their numbers in this assay, from the lowest: compounds 4 and 3 (each within the scatter of the next); then compounds 1 and 2 (each within the scatter of the next).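

In this assay, cyano in place of benzoyl gave a number 2 percentage points lower from compound 3 to compound 4 (within the scatter), so on this aromatic carbon, para to a large group, going from benzoyl with 8 heavy atoms to cyano with 2 left the number within the scatter. Hydroxy now stands apart from two replacements rather than one: cyano in place of hydroxy gave a number 15 percentage points lower from compound 1 to compound 4 (beyond the scatter), in the same direction as benzoyl in place of hydroxy, which gave a number 13 percentage points lower from compound 1 to compound 3 (beyond the scatter). Nothing in the data available here explains these numbers.

From the compounds shown here alone, whether an amine or a carboxylic acid on this carbon would read with hydroxy, or with cyano and benzoyl, remains open. Also open, going by these compounds, is how these compounds would compare at other concentrations, as each is read at a single one.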